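Swapping One Fluorinated Group in a Cell Growth Test

A few compounds are considered here, and "the series" means these few. Any claim that something is new, unique, unknown or untested is made for them only; others in the source may bear on it.

Of the compounds shown here, three have been measured in a functional assay on VCaP cells (Homo sapiens) for antiproliferative activity, read by propidium iodide staining, with a stated time of 96 h; a higher number here means a weaker inhibitor, a lower number a stronger inhibitor. Compound 1 `CC(O)(CSc1ccc(F)cc1)C(=O)Nc1cccc(S(F)(F)(F)(F)F)c1` gives 21900 nM and compound 3 `CC(O)(COc1cccc(S(F)(F)(F)(F)F)c1)C(=O)Nc1cccc(S(F)(F)(F)(F)F)c1` gives 26700 nM, two values within the scatter of each other. Compound 2 `CC(O)(COc1ccc(S(F)(F)(F)(F)F)cc1)C(=O)Nc1ccc([N+](=O)[O-])c(C(F)(F)F)c1` gives 100000 nM, a clearly higher number than compound 3 shows, which marks a weaker inhibitor. Compound 3 therefore stands level with compound 1 and well clear of compound 2.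

Compound 4 `CC(O)(COc1cccc(OC(F)(F)F)c1)C(=O)Nc1cccc(S(F)(F)(F)(F)F)c1` changes compound 3 in one place: a group of 5 heavy atoms (1 carbon, 1 oxygen, 3 fluorine; no ring) in place of a group of 6 heavy atoms (5 fluorine, 1 sulfur; no ring), on an aromatic carbon. The entering group is trifluoromethoxy, on an aromatic carbon of a six-membered aromatic ring of carbon only, meta to a large group. Within the data shown here, no measured pair differs in one place alone, so there is no direct precedent. Still, compound 1, whose 21900 nM lies within the scatter of compound 3, carries a different group on that ring, so no change beyond the scatter is expected in this assay. The expected result is a 1.1-fold higher number from compound 3 to compound 4 (0.05 log units; within the scatter). For compound 4 the estimated value is 30000 nM, with an expected range from 12000 nM to 75000 nM.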

Compound 4, half-maximal inhibitory concentration: 28600 nM
Estimate against measurement, compound 4: 1.0-fold (0.02 log units) above; measured number inside the range.
By their numbers in this assay, from the lowest: compounds 1, 3 and 4 (each within the scatter of the next); then compound 2.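

In this assay, putting trifluoromethoxy in place of the group of 5 fluorine and 1 sulfur, on an aromatic carbon meta to a large group, gives a 1.1-fold higher number from compound 3 to compound 4 (0.03 log units; within the scatter). Among these compounds, this is the first comparison in the set that differs in one place alone, and it shows that the two groups cannot be told apart at this position in this assay, even though the entering group counts 1 hydrogen-bond acceptor and the leaving group 0. No measurement is available to explain why the two groups read alike.

Still open, on these data alone, is whether an amine, a carboxylic acid or a longer chain at this position would move the number beyond the scatter. Also open, as far as these compounds go, is whether the same swap would read alike on the other aromatic ring, which still carries the group of 5 fluorine and 1 sulfur in compound 4.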